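Methoxy for Fluoro on an Aromatic Carbon

This account rests on a few compounds, and the source may have more. Where it says the series, first, only, none or still open, it means among the compounds named here.

Of the compounds shown here, three that share one core have been measured in an assay on isolated protein for inhibition of histone deacetylase 8 (Homo sapiens), with a stated time of 1 h; on this read-out higher numbers stand for weaker inhibition and lower numbers for stronger inhibition. Compound 1 `Cc1ccc(NC(=O)COc2ccc3cc(/C=C4/SC(=O)NC4=O)ccc3c2)cc1` gives 9000 nM. Compound 2 `O=C(COc1ccc2cc(/C=C3/SC(=O)NC3=O)ccc2c1)Nc1ccccc1`, which carries hydrogen in place of methyl on an aromatic carbon, gives 4500 nM. Compound 3 `O=C(COc1ccc2cc(/C=C3/SC(=O)NC3=O)ccc2c1)Nc1ccc(F)cc1` gives 6600 nM. Among these three numbers compound 3 stands second highest; its nearest neighbour is compound 1 and its furthest is compound 2, and both of those gaps lie within the scatter of this assay.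

Compound 4 `COc1ccc(NC(=O)COc2ccc3cc(/C=C4/SC(=O)NC4=O)ccc3c2)cc1` has not yet been measured. It differs from compound 3 in one place: methoxy in place of fluoro on an aromatic carbon.

The measured steps that bear on this change are those that alter the group on the same aromatic carbon. a 1.4-fold lower number from compound 1 to compound 3 (0.13 log units; within the scatter) and a 1.5-fold higher number from compound 2 to compound 3 (0.17 log units; within the scatter) both stayed within the scatter, as did a 2.0-fold lower number from compound 1 to compound 2 (0.30 log units; within the scatter). None of the three measured numbers shows that exchanging the group on this carbon shifts the read-out of this assay beyond the scatter, so for compound 4 a step of a 1.1-fold higher number from compound 3 to compound 4 (0.03 log units; within the scatter) is expected, that is, nothing beyond the scatter in either direction. Compound 4 is therefore estimated at 7000 nM in this assay, with a range from 3000 nM to 16000 nM.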

Compound 4, half-maximal inhibitory concentration: > 50000 nM
Compound 4 ended at the assay's limit (the forecaster's own chance of this, stated with the estimate: 5%); at least 7.1-fold (0.85 log units) between middle value and limit.
By their numbers in this assay, from the lowest: compounds 2, 3 and 1 (each within the scatter of the next). At a limit, above all of these: compound 4.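

In this assay, going by these compounds alone, methoxy is the first group on this aromatic carbon, para to a large group, to move the read-out beyond the scatter: an at least 7.5-fold higher number from compound 3 to compound 4 (0.87 log units; beyond the scatter), an at least 11-fold higher number from compound 2 to compound 4 (1.04 log units; beyond the scatter) and an at least 5.5-fold higher number from compound 1 to compound 4 (0.74 log units; beyond the scatter). The earlier compounds shown here, with hydrogen, methyl and fluoro at this carbon, lay within the scatter of each other and gave no sign that the position responds to what it carries, whereas this exchange shows that it does, with inhibition weakened against all three. The value of compound 4 is a limit of the assay and not a number, so these steps fix only a lower bound on the change: the limit of > 50000 nM in this assay, at which 1 of the 4 values shown sits.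

The compounds shown leave open whether this weakening belongs to methoxy alone or would also appear with hydroxy, ethoxy, chloro or an amine on the same carbon. They also leave open whether a longer chain ending in an ether oxygen would behave like methoxy, and how far above the limit compound 4 truly lies.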